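Swapping the benzyl substituent toward a dimethoxy pattern

The source may hold more compounds than are shown below. What is called first, only, known or untested is meant among the compounds shown, and "the series" means these compounds.

Measured compounds:
Compound 1 `COc1ccc2nc(SCC(=O)N(Cc3ccc(OC)c(O)c3)c3cc(OC)c(OC)c(OC)c3)sc2c1`: 352 nM
Compound 2 `COc1cc(N(Cc2ccc(C)cc2)C(=O)CSc2nc3ccccc3s2)cc(OC)c1OC`: > 80000 nM
Compound 3 `COc1cc(N(Cc2ccc(Br)cc2)C(=O)CSc2nc3ccccc3s2)cc(OC)c1OC`: 63800 nM

Of the compounds shown here, three have been measured in a functional assay on HCT-116 cells (Homo sapiens) for antiproliferative activity, read by MTT assay, with a stated time of 48 h; on this read-out higher numbers stand for weaker inhibition and lower numbers for stronger inhibition. Compound 1 gives 352 nM. Compound 2 reaches only the limit of the assay, at > 80000 nM, so no number is known for it (the limit of > 80000 nM in this assay, at which 1 of the 3 values shown sits). Compound 3 gives 63800 nM, the highest number among the two compounds for which a number exists; its nearest neighbour on the scale is compound 1, whose number is far lower, beyond the scatter. Within the data shown here, the one measured step, bromo in place of methyl on an aromatic carbon, is an at least 1.2-fold lower number from compound 2 to compound 3 (0.09 log units; that floor lies within the scatter), and it tells little because one of its two ends is a limit.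

Compound 4 `COc1ccc(CN(C(=O)CSc2nc3ccccc3s2)c2cc(OC)c(OC)c(OC)c2)cc1OC` has not yet been measured. It differs from compound 3 as follows: 3,4-dimethoxyphenyl in place of 4-bromophenyl on a saturated chain carbon bound to an amide-type nitrogen. Among the measured compounds shown here, no measured step matches this change. For the measured compounds named here, compound 1, which differs from compound 4 in more than one place, is the only compound carrying oxygen substituents on that ring, and it has by far the lowest number. Compound 4 is therefore expected to sit between compound 3 and compound 1, and the step from compound 3 is estimated as a 13-fold lower number from compound 3 to compound 4 (1.11 log units; beyond the scatter). The estimate for compound 4 is 5000 nM, with a range from 500 nM to 50000 nM.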

Compound 4, half-maximal inhibitory concentration: 33900 nM
Compound 4: middle estimate off by 6.8-fold (0.83 log units), on the low side; low and high end bracket the measured number.
By their numbers in this assay, from the lowest: compound 1; then compounds 4 and 3 (each within the scatter of the next). At a limit, above all of these: compound 2.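

In this assay, 3,4-dimethoxyphenyl in place of 4-bromophenyl on a saturated chain carbon bound to an amide-type nitrogen gives a 1.9-fold lower number from compound 3 to compound 4 (0.27 log units; within the scatter), so on this core the change does not move the number beyond the scatter. Among these compounds, measured against 4-methylphenyl at the same place, the same group gives an at least 2.3-fold lower number from compound 2 to compound 4 (0.37 log units; beyond the scatter), which is the first step at this position to clear the scatter, though only modestly. Compound 2 carries a limit and not a number, so that step is a floor and its true size is unknown: the limit of > 80000 nM in this assay, at which 1 of the 4 values shown sits.

Compound 1 differs from compound 4 in more than one place, so the compounds shown do not tell which of those differences goes with its much lower number. As far as these compounds go, it also stays open how this position would read with a group of another kind on the saturated chain carbon bound to an amide-type nitrogen, such as an amine or a carboxylic acid on the phenyl ring.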